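The compounds below may be only part of what the source reports. "The series", "measured", "known", "first", "only" and "open" are said of these compounds alone.

Measured compounds:
compound 1 `O=S(=O)(NCCNCc1cccc2ccccc12)c1cc(C(F)(F)F)cc(C(F)(F)F)c1` with 22000 nM
compound 2 `O=S(=O)(NCCNCc1ccc(-c2ccccc2)cc1)c1cc(C(F)(F)F)cc(C(F)(F)F)c1` with 2800 nM

Both numbers come from a functional assay on ASPC1 cells (Homo sapiens) for inhibition, read by MTT assay, with a stated time of 72 h; on this read-out lower numbers stand for stronger inhibition of growth and higher numbers for weaker inhibition of growth. Compound 2 stands lowest of the two, and compound 1 gives a number that is higher by a margin that is beyond the usual scatter, so among the measured compounds compound 2 is the stronger inhibitor of growth.

Compound 3 `CC(C)(C)c1ccc(CNCCNS(=O)(=O)c2cc(C(F)(F)F)cc(C(F)(F)F)c2)cc1` has not yet been measured in this assay. It differs from compound 2 in one place: tert-butyl in place of phenyl on an aromatic carbon. Going by the values given here, no measured pair shows this change, so its effect in this assay is unknown; the two measured numbers only show that a change of the aromatic part of the molecule can move the number by a large amount.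

Compound 3 is therefore expected to land near compound 2, with a modest step from compound 2 to compound 3 of a 1.4-fold higher number from compound 2 to compound 3 (0.15 log units; within the scatter) toward a higher number, but a step not clearly beyond the scatter. The estimate for compound 3 in this assay is 4000 nM, with a range from 1500 nM to 12000 nM.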

Compound 3, concentration for 50% growth inhibition: 14000 nM
Compound 3: the middle estimate sits 3.5-fold (0.54 log units) below what was measured; measured number above the stated range.
By their numbers in this assay, from the lowest: compound 2; then compounds 3 and 1 (each within the scatter of the next).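

In this assay, the group on an aromatic carbon para to a large group proves to matter: tert-butyl in place of phenyl gives a 5.0-fold higher number from compound 2 to compound 3 (0.70 log units; beyond the scatter) and so loses most of what compound 2 had gained, which means that this place does not treat these two carbon-only groups alike. The step from naphthalen-1-yl to 4-(tert-butyl)phenyl on the saturated chain carbon gives a 1.6-fold lower number from compound 1 to compound 3 (0.20 log units; within the scatter) and stays within the scatter, so that compound 2 alone stands apart as the strongest inhibitor of growth of the three, and neither an added bulky carbon group nor a second fused aromatic ring matches the phenyl. Nothing measured here explains why the phenyl compound stands apart.

From the compounds shown here alone, what remains open is whether the aromatic character of the phenyl ring counts at this place, or only the presence of a ring, which a cyclohexyl ring or a pyridine ring in its position would begin to settle. Going by these compounds, it is also open whether a substituent on the phenyl ring itself, such as a methoxy group or a fluorine, would keep or improve the number of compound 2.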